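Swapping the amide substituent on a second chlorinated core

The compounds below may be only part of what the source reports. "The series", "measured", "known", "first", "only" and "open" are said of these compounds alone.

The study compares four compounds that share an amide attached to a bicyclic core and differ in the group on the amide nitrogen or in the core itself. Compound 1 `COCCNC(=O)c1cc2cccc(OC)c2oc1=N` carries a 2-methoxyethyl group on the amide nitrogen; in an assay on HEK293 cells for displacement of a labelled ligand from adenosine receptor A2b (Homo sapiens), read by scintillation counting, with a stated time of 30 min, tested at 10 uM (a lower number here means less inhibition, a higher number more inhibition at the concentration tested (going by the name of the read-out)), compound 1 gives 43%. Compound 2 `CCC(CO)NC(=O)c1cc2cccc(OC)c2oc1=N` carries instead a 1-(hydroxymethyl)propyl group, the change being (1-(hydroxymethyl)propyl in place of 2-methoxyethyl on an amide-type nitrogen). In this assay compound 2 gives 39%, so the step of a number 4 percentage points lower from compound 1 to compound 2 (within the scatter) is one that does not separate the two compounds.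

Compound 3 `COCCNC(=O)c1cc2cc(Cl)ccc2oc1=N` keeps the 2-methoxyethyl group but sits on a different core; the difference between the two cores is not broken down here. In this assay compound 3 gives 9%, the lowest of the three numbers and beyond the scatter from both compound 1 and compound 2.

Compound 4 `CCC(CO)NC(=O)c1cc2cc(Cl)ccc2oc1=N` combines the core of compound 3 with the 1-(hydroxymethyl)propyl group, the change being (1-(hydroxymethyl)propyl in place of 2-methoxyethyl on an amide-type nitrogen), the same change already seen from compound 1 to compound 2. Because that earlier step was a number 4 percentage points lower from compound 1 to compound 2 (within the scatter), the step from compound 3 to compound 4 is expected to be of similar small size, a number 2 percentage points lower from compound 3 to compound 4 (within the scatter), and compound 4 is expected to give about 7% in this assay, within 0% to 20%. This rests on a single prior occurrence of the change.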

Compound 4, a percentage reported as inhibition, at one concentration (the size of the read-out at that concentration, not a potency): 9%
Estimate against measurement, compound 4: 2 percentage points below; the range from low to high includes it.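

Set on the second core, the swap of 2-methoxyethyl for 1-(hydroxymethyl)propyl on the amide-type nitrogen gives, in this assay, no change at the digits printed from compound 3 to compound 4 (within the scatter), and the comparison with the earlier step reads: the same change on two cores in this assay, a number 4 percentage points lower (within the scatter) from compound 1 to compound 2 and no change at the digits printed (within the scatter) from compound 3 to compound 4, 4 percentage points apart, within the scatter of two such steps. This shows that, on the two cores tested, the change carries over as a step too small to separate the compounds in either pair, so the two groups cannot be told apart by this read-out on either core. Within the data shown here, it does not show that the two groups are equivalent on any other core, and with only two occurrences of the change, each read at a single concentration, it says nothing about potency or about a difference smaller than the scatter.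

The compounds shown leave open whether other groups on the amide nitrogen, such as a longer alkyl chain, a chain ending in an amine or one ending in a carboxylic acid, would move the number on either core. Also open is which feature of the two cores accounts for the gap between them, as no pair here differs in one place on the core alone.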